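Swapping methoxy for methylsulfanyl on the pyridine of compound 2

A few compounds are considered here, and "the series" means these few. Any claim that something is new, unique, unknown or untested is made for them only; others in the source may bear on it.

Measured compounds:
Compound 1, `COc1cc([C@](O)(CCN(C)C)[C@@H](c2cc3cc(Br)ccc3nc2OC)c2cccc(OC)c2F)cc(SC)n1`, 4.8 uL/min
Compound 2, `COc1cc([C@](O)(CCN(C)C)[C@@H](c2cc3cc(C#N)ccc3nc2OC)c2cccc(OC)c2F)cc(SC)n1`, 16 uL/min

In an ADME assay on microsomes from liver (Homo sapiens) for metabolic stability (a lower number here means slower removal, a higher number faster removal of the compound), compound 2 gives the higher of the two numbers, and its nearest neighbour is compound 1. Among the measured compounds shown here, the one step between the measured compounds, a 3.3-fold higher number from compound 1 to compound 2 (0.52 log units; beyond the scatter), exchanges a bromo for a cyano on an aromatic carbon and lies in a different part of the shared core from the change considered here.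

Compound 3, `COc1cccc([C@H](c2cc3cc(C#N)ccc3nc2OC)[C@@](O)(CCN(C)C)c2cc(SC)nc(SC)c2)c1F`, differs from compound 2 by methylsulfanyl in place of methoxy on an aromatic carbon. For the measured compounds named here, no measured step changes this part of the core, so the measured numbers give no direct guide to how far this exchange moves the read-out. Without such a guide, a step within the usual scatter is the plain expectation, with wide uncertainty on either side. The estimated step is a 1.3-fold higher number from compound 2 to compound 3 (0.10 log units; within the scatter). Compound 3 is therefore expected to give about 20 uL/min, within the range 8 uL/min to 50 uL/min.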

Compound 3, intrinsic clearance in a liver preparation (reported as CLH), per the amount of preparation that the assay uses: 15 uL/min
Beside the measured number, compound 3's estimate is 1.3-fold (0.12 log units) above it; low and high end bracket the measured number.
By their numbers in this assay, from the lowest: compound 1; then compounds 3 and 2 (each within the scatter of the next).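

In this assay the exchange at this position, next to the ring nitrogen, gives a 1.1-fold lower number from compound 2 to compound 3 (0.03 log units; within the scatter), so methoxy and methylsulfanyl cannot be told apart here. Compound 3 carries methylsulfanyl at this position as well as the methylsulfanyl group already on the same ring, and this second one leaves the read-out within the scatter of compound 2. Nothing available explains this result.

The compounds shown leave open what happens at this position with a group of another kind, such as an amine or a longer chain like butoxy. They also leave open whether the exchange of methoxy for methylsulfanyl gives a similar result when bromo, as in compound 1, stands in place of the cyano group.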